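Ortho-Methoxyphenyl in Place of Methylsulfanylphenyl

The source may report more compounds than this note shows. Statements on the series, on what has been measured and on what is new or still open speak of the compounds shown alone.

Three compounds share one core and differ only in the aryl group attached to it. Compound 1 `CCC1=C(O)c2c(oc(-c3ccc(CC(C)C)cc3)cc2=O)C(CC)(CC)C1=O` gives 17.4 uM in a functional assay on KBVIN cells (Homo sapiens) for antiproliferative activity, read by sulforhodamine B assay, with a stated time of 3 days; on this read-out higher numbers stand for an effect only at larger amounts of compound and lower numbers for an effect already at smaller amounts. Compound 2 `CCC1=C(O)c2c(oc(-c3ccc(OC(F)(F)F)cc3)cc2=O)C(CC)(CC)C1=O` gives 9.95 uM, and compound 3 `CCC1=C(O)c2c(oc(-c3ccc(SC)cc3)cc2=O)C(CC)(CC)C1=O` gives 1.38 uM, the lowest of the three numbers. The steps of a 13-fold lower number from compound 1 to compound 3 (1.10 log units; beyond the scatter) and a 7.2-fold lower number from compound 2 to compound 3 (0.86 log units; beyond the scatter) both lie beyond the scatter, so compound 3 stands apart as the most active of the measured set, while a 1.7-fold lower number from compound 1 to compound 2 (0.24 log units; within the scatter) is within the scatter.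

Compound 4 `CCC1=C(O)c2c(oc(-c3ccccc3OC)cc2=O)C(CC)(CC)C1=O` is not yet measured. Its change from compound 3 is 2-methoxyphenyl in place of 4-(methylsulfanyl)phenyl on an aromatic carbon. For the measured compounds named here, none of the measured steps bears directly on this change: each of them exchanges one group for another on the aryl ring, whereas here the whole 2-methoxyphenyl replaces the 4-(methylsulfanyl)phenyl. Since the gain seen in compound 3 is tied to the methylsulfanyl group that now leaves, compound 4 is expected to lose it and fall back toward compounds 1 and 2, a step of a 6.5-fold higher number from compound 3 to compound 4 (0.81 log units; beyond the scatter). The estimate for compound 4 is therefore 9 uM, with a range from 2.5 uM to 30 uM.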

Compound 4, concentration for half-maximal effect: 3.26 uM
The estimate for compound 4 lay 2.8-fold (0.44 log units) above the measured number; low and high end bracket the measured number.
By their numbers in this assay, from the lowest: compound 3; then compound 4; then compounds 2 and 1 (each within the scatter of the next).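

Replacing 4-(methylsulfanyl)phenyl with 2-methoxyphenyl gives a 2.4-fold higher number from compound 3 to compound 4 (0.37 log units; beyond the scatter) in this assay and so compound 3 keeps the lowest number, but the methylsulfanyl group is not essential for a low number. Compound 4 at 3.26 uM still lies below compound 2 at 9.95 uM and compound 1 at 17.4 uM and thus shows that an aryl group without sulfur can come fairly close to compound 3. Nothing available explains the gap between compound 3 and compound 4.

This single swap changes both the group and its place on the aryl ring, so the two contributions cannot be separated. From the compounds shown here alone, a 4-methoxyphenyl or a 2-(methylsulfanyl)phenyl group would each change only one of them, and the effect of an amine on that ring also remains open.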